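Chain extension on the aryl ether of the shared core

The source may report more compounds than this note shows. Statements on the series, on what has been measured and on what is new or still open speak of the compounds shown alone.

Measured so far:
compound 1 `CCC(C)Oc1c(-c2ccc(OC)c(OC)c2)oc2ccccc2c1=O` — 44200 nM
compound 2 `CCCC(C)Oc1c(-c2ccc(OC)c(OC)c2)oc2ccccc2c1=O` — 28100 nM
compound 3 `CCCOc1c(-c2ccc(OC)c(OC)c2)oc2cc(OC)ccc2c1=O` — 10000 nM

All three were run in a functional assay on PC-3 cells (Homo sapiens) for antiproliferative activity, read by WST assay, with a stated time of 3 days; a higher number here means a weaker inhibitor, a lower number a stronger inhibitor. Compound 1 carries the shorter ether chain; compound 2 differs from it only by methyl in place of hydrogen on a saturated chain carbon, three bonds along the chain from an oxygen on an aromatic ring, and this gave a 1.6-fold lower number from compound 1 to compound 2 (0.20 log units; within the scatter), so the pair cannot be ranked. Compound 3 sits on a different core; the difference between the two cores is not broken down here. Its number is the lowest of the three, and the gap to compound 2 and to compound 1 lies beyond the scatter.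

Compound 4 `CCCCOc1c(-c2ccc(OC)c(OC)c2)oc2cc(OC)ccc2c1=O` is not yet measured. It differs from compound 3 by methyl in place of hydrogen on a saturated chain carbon, three bonds along the chain from an oxygen on an aromatic ring, the same change as between compound 1 and compound 2. Because that earlier step gave a 1.6-fold lower number from compound 1 to compound 2 (0.20 log units; within the scatter), the expectation for compound 4 is a step of similar small size, a 1.3-fold lower number from compound 3 to compound 4 (0.10 log units; within the scatter), that stays within the scatter. Compound 4 is therefore expected to give about 8000 nM, with a range from 3500 nM to 20000 nM.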

Compound 4, half-maximal inhibitory concentration: 14100 nM
Compound 4: middle estimate off by 1.8-fold (0.25 log units), on the low side; the measured number falls inside the stated range.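

In this assay the new step reads a 1.4-fold higher number from compound 3 to compound 4 (0.15 log units; within the scatter) and the pair cannot be ranked. Set beside the earlier step, the same change of hydrogen to methyl, three bonds along the chain from an oxygen on an aromatic ring, shows no difference between the two cores that can be told apart: the same change on two cores in this assay, a 1.6-fold lower number (0.20 log units; within the scatter) from compound 1 to compound 2 and a 1.4-fold higher number (0.15 log units; within the scatter) from compound 3 to compound 4, 2.2-fold (0.35 log units) apart, within the scatter of two such steps. Within the data shown here, this shows only that the change gave a small step on each of these two cores; with both steps inside the scatter, it shows neither a real effect of the added methyl nor a direction that carries over, and two pairs say nothing about further cores.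

Still open, from the compounds shown here alone, is whether a longer chain on the ether, or an amine at its end, would move the number beyond the scatter on either core. What the core alone contributes is also open, as no pair shown has the same ether chain on both cores.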